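Restoring a piperazine on the piperidine: expected gain

The compounds below may be only part of what the source reports. "The series", "measured", "known", "first", "only" and "open" are said of these compounds alone.

Compound 1 `COc1cc(C)c(S(=O)(=O)N(C)CCOCC(=O)N2CCC(N3CCN(C(C)C)CC3)CC2)c(C)c1`: in an assay on HEK293 cells for displacement of a labelled ligand from B1 bradykinin receptor (Homo sapiens), read by scintillation counting (on this read-out lower numbers stand for stronger inhibition and higher numbers for weaker inhibition), compound 1 gives 3.8 nM
Compound 2 `COc1cc(C)c(S(=O)(=O)N(C)CCOCC(=O)N2CCC(C(O)CN(C)C)CC2)c(C)c1`: in this assay compound 2 gives 30 nM

Among the measured compounds shown here, of the two numbers, compound 2 has the higher one; the only measured step is a 7.9-fold higher number from compound 1 to compound 2 (0.90 log units; beyond the scatter). Compound 3 `COc1cc(C)c(S(=O)(=O)N(C)CCOCC(=O)N2CCC(CN3CCN(C)CC3)CC2)c(C)c1` differs from compound 2 by (4-methylpiperazin-1-yl)methyl in place of 2-(dimethylamino)-1-hydroxyethyl on a saturated ring carbon. This reinstates a piperazinyl group resembling the 4-isopropylpiperazin-1-yl of compound 1, so the number is expected to fall because a 7.9-fold higher number from compound 1 to compound 2 (0.90 log units; beyond the scatter) shows that losing such a group raised it. Compound 3 is therefore estimated at 6 nM, likely between 2 nM and 20 nM. This implies an expected step of a 5.0-fold lower number from compound 2 to compound 3 (0.70 log units; beyond the scatter).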

Compound 3, inhibition constant: 4.7 nM
The estimate for compound 3 lay 1.3-fold (0.11 log units) above the measured number; the range from low to high includes it.
By their numbers in this assay, from the lowest: compounds 1 and 3 (each within the scatter of the next); then compound 2.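

In this assay, a piperazine on this saturated ring carbon again goes with the lower number, with a 6.4-fold lower number from compound 2 to compound 3 (0.81 log units; beyond the scatter). Exchanging 4-isopropylpiperazin-1-yl for (4-methylpiperazin-1-yl)methyl makes no measurable difference, with a 1.2-fold higher number from compound 1 to compound 3 (0.09 log units; within the scatter). No measurement shown explains either step. The step from compound 2 to compound 3 also removes the hydroxyl, so the share of each change in it stays unresolved. Also open, from the compounds shown here alone, is how a morpholin-4-ylmethyl group, with an oxygen in place of one ring nitrogen, would compare.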